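Fluoro in place of hydrogen on compound 2

This account rests on a few compounds, and the source may have more. Where it says the series, first, only, none or still open, it means among the compounds named here.

In an ADME assay on THP-1 cells (Homo sapiens) for cytotoxicity, read by flow cytometry and propidium iodide staining, with a stated time of 72 h (a lower number here means a stronger inhibitor, a higher number a weaker inhibitor), compound 1 `CC(=O)Nc1ccc(O)c(C(=O)/C=C/c2ccccc2F)c1` gives > 125000 nM, which is a limit of the assay and not a number. Going by the values given here, compound 2 `CC(=O)Nc1ccc2oc(-c3ccccc3)cc(=O)c2c1` gives 97000 nM, the higher of the two actual numbers so far. Compound 3 `COc1cccc(-c2cc(=O)c3cc(NC(C)=O)ccc3o2)c1` gives 10000 nM. Compound 4 `CC(=O)Nc1ccc2oc(-c3ccc(F)cc3)cc(=O)c2c1` is still unmeasured and differs from compound 2 by fluoro in place of hydrogen on an aromatic carbon. Among the compounds with values here, one measured step bears on this change, methoxy in place of hydrogen, a 9.7-fold lower number from compound 2 to compound 3 (0.99 log units; beyond the scatter). With that single step as the guide, a smaller move in the same direction is expected in this assay. The expected step is a 1.6-fold lower number from compound 2 to compound 4 (0.21 log units; within the scatter). For compound 4 the estimate is 60000 nM, with an expected range of 20000 nM to 125000 nM.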

Compound 4, half-maximal inhibitory concentration: 22000 nM
Beside the measured number, compound 4's estimate is 2.7-fold (0.44 log units) above it, within the range that was stated.
By their numbers in this assay, from the lowest: compound 3; then compound 4; then compound 2. At a limit, above all of these: compound 1.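

In this assay the change from phenyl to 4-fluorophenyl gives a 4.4-fold lower number from compound 2 to compound 4 (0.64 log units; beyond the scatter), so a single heavy atom on an aromatic carbon, para to a large group, is enough to move the number beyond the scatter. With the methoxy step, a 9.7-fold lower number from compound 2 to compound 3 (0.99 log units; beyond the scatter), two single changes to compound 2 now lower the number, and neither goes against the other. Nothing shown bears on why the fluoro step arises.

On these data alone, whether this lowering is specific to fluoro stays open. Chloro, an amine or a carboxylic acid on the same carbon would begin to answer that.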